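Expected Cell Toxicity After Replacing Aminophenyl With Trifluoromethylphenyl

A few compounds are considered here, and "the series" means these few. Any claim that something is new, unique, unknown or untested is made for them only; others in the source may bear on it.

Of the compounds shown here, three sharing one core have been tested in an ADME assay on Huh-7 cells (Homo sapiens) for cytotoxicity; on this read-out higher numbers stand for lower toxicity in this test and lower numbers for higher toxicity in this test. Compound 1 `Cc1ccccc1-c1nn(-c2cccc(Cl)c2)cc1CNCCN1CCN(C)CC1` gives 16000 nM. Compound 2 `Cc1ccccc1-c1nn(-c2ccc(Br)cc2)cc1CNCCN1CCN(C)CC1` gives 9600 nM, a change of a 1.7-fold lower number from compound 1 to compound 2 (0.22 log units; within the scatter). Compound 3 `Cc1ccccc1-c1nn(-c2ccc(N)cc2)cc1CNCCN1CCN(C)CC1` reaches only the limit of > 20000 nM, so its number is known only as a boundary (the limit of > 20000 nM in this assay, at which 1 of the 3 values shown sits). Accordingly the steps of an at least 1.2-fold higher number from compound 1 to compound 3 (0.09 log units; that floor lies within the scatter) and an at least 2.0-fold higher number from compound 2 to compound 3 (0.31 log units; beyond the scatter) carry floors rather than exact sizes. Compound 4 `Cc1ccccc1-c1nn(-c2cccc(C(F)(F)F)c2)cc1CNCCN1CCN(C)CC1` is unmeasured; its change from compound 3 is 3-(trifluoromethyl)phenyl in place of 4-aminophenyl on an aromatic nitrogen. The nearest comparison is compound 1, which carries 3-chlorophenyl at the same aromatic nitrogen and gave 16000 nM. Compound 4 is therefore estimated at 14000 nM, within 6000 nM to 30000 nM. That estimate corresponds to an expected step of an at least 1.4-fold lower number from compound 3 to compound 4 (0.15 log units; that floor lies within the scatter), within the scatter.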

Compound 4, half-maximal cytotoxic concentration: 18000 nM
The estimate for compound 4 lay 1.3-fold (0.11 log units) below the measured number; the range from low to high includes it.
By their numbers in this assay, from the lowest: compounds 2, 1 and 4 (each within the scatter of the next). At a limit, above all of these: compound 3.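

In this assay, trifluoromethyl in place of chloro gives a 1.1-fold higher number from compound 1 to compound 4 (0.05 log units; within the scatter), and 3-(trifluoromethyl)phenyl in place of 4-bromophenyl gives a 1.9-fold higher number from compound 2 to compound 4 (0.27 log units; within the scatter), so neither step separates these groups on this aromatic nitrogen. Compound 3 stands at a limit, not at a number: the limit of > 20000 nM in this assay, at which 1 of the 4 values shown sits. The step away from it is therefore only a floor, an at least 1.1-fold lower number from compound 3 to compound 4 (0.04 log units; that floor lies within the scatter), and it does not show how far 4-aminophenyl and 3-(trifluoromethyl)phenyl truly differ.

Still open, from the compounds shown here alone, is how far the true number of compound 3 lies past its limit. Also open, going by these compounds, is whether a carboxylic acid or a nitrile on this phenyl group would give a step beyond the scatter.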